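Carbamate series on pancreatic cells: trifluoromethyl swap on longer chain

The compounds below may be only part of what the source reports. "The series", "measured", "known", "first", "only" and "open" are said of these compounds alone.

Compound 1 `CC(C)=CCC1Cc2c(OC(=O)Nc3ccc(Cl)cc3)cc(=O)n(CCCO)c2CC1(C)C` is the reference point of this set; in a functional assay on PANC-1 cells (Homo sapiens) for inhibition, read by MTT assay, with a stated time of 24 h, tested at 10 uM (on this read-out higher numbers stand for more inhibition at the one concentration tested (going by the name of the read-out) and lower numbers for less inhibition), compound 1 gives 0%. Compound 2 `CC(C)=CCC1Cc2c(OC(=O)Nc3cccc(C(F)(F)F)c3)cc(=O)n(CCCO)c2CC1(C)C` carries 3-(trifluoromethyl)phenyl in place of 4-chlorophenyl on an amide-type nitrogen, and in this assay compound 2 gives 0%, so that no change at the digits printed from compound 1 to compound 2 (within the scatter).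

Compound 3 `CC(C)=CCC/C(C)=C/CC1Cc2c(OC(=O)Nc3ccc(Cl)cc3)cc(=O)n(CCCO)c2CC1(C)C` is the longer-chain analogue of compound 1, and in this assay compound 3 gives 4.3%; the step is a number 4.3 percentage points higher from compound 1 to compound 3 (within the scatter). Compound 3 has the highest of the three numbers, but its gaps to compound 1 and to compound 2 both fall within the scatter, so no ranking of the three is supported.

Compound 4 `CC(C)=CCC/C(C)=C/CC1Cc2c(OC(=O)Nc3cccc(C(F)(F)F)c3)cc(=O)n(CCCO)c2CC1(C)C` has not been measured. It stands to compound 3 as compound 2 stands to compound 1: the change is 3-(trifluoromethyl)phenyl in place of 4-chlorophenyl on an amide-type nitrogen. The two cores differ by 3-methylbut-2-en-1-yl in place of hydrogen on a saturated chain carbon bound to a double-bonded chain carbon. The place of the change reads the same in both pairs, so this is the same change, made twice in the set. For compound 4 the expected step from compound 3 is a number 1.3 percentage points lower from compound 3 to compound 4 (within the scatter), set beside the measured no change at the digits printed from compound 1 to compound 2 (within the scatter); the expectation rests on that earlier step showing no change and on compound 3 sitting at 4.3%. Compound 4 is therefore estimated to give 3% in this assay, with an expected range from 0% to 12%.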

Compound 4, a percentage reported as inhibition, at one concentration (the size of the read-out at that concentration, not a potency): 6.7%
Compound 4: middle estimate off by 3.7 percentage points, on the low side; the range from low to high includes it.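

In this assay, 3-(trifluoromethyl)phenyl in place of 4-chlorophenyl on the amide-type nitrogen of the longer-chain core reads as a number 2.4 percentage points higher from compound 3 to compound 4 (within the scatter), and this agrees with the same swap on the shorter-chain core: the same change on two cores in this assay, no change at the digits printed (within the scatter) from compound 1 to compound 2 and a number 2.4 percentage points higher (within the scatter) from compound 3 to compound 4, 2.4 percentage points apart, within the scatter of two such steps

The chain change, 3-methylbut-2-en-1-yl in place of hydrogen, now read on the 3-(trifluoromethyl)phenyl side, is a number 6.7 percentage points higher from compound 2 to compound 4 (within the scatter), and it also agrees with its earlier reading on the 4-chlorophenyl side: the same change on two cores in this assay, a number 4.3 percentage points higher (within the scatter) from compound 1 to compound 3 and a number 6.7 percentage points higher (within the scatter) from compound 2 to compound 4, 2.4 percentage points apart, within the scatter of two such steps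

Both changes therefore carry from one core to the other with no difference this read-out can separate, but this does not show that either change has any effect of its own, as that would need a step beyond the scatter on at least one core.

Going by these compounds alone, it remains open whether any other substituent on the amide-type nitrogen, such as a phenyl ring bearing an amine or a carboxylic acid, or a chain longer than the one in compound 4, would give a step beyond the scatter. With a single concentration and a single cell line shown, the four compounds also leave open how they would behave at other concentrations or on other cells.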